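A few compounds are considered here, and "the series" means these few. Any claim that something is new, unique, unknown or untested is made for them only; others in the source may bear on it.

Measured so far:
compound 1 `Cc1nnc(CN(C)C)n1-c1ccc(Cl)cc1C(=O)c1ccccc1`: 45 mg/kg
compound 2 `CN(C)CCn1nc(CN(C)C)n(-c2ccc(Cl)cc2C(=O)c2ccccc2)c1=O`: a limit, > 100 mg/kg
compound 3 `Cc1nnc(CN)n1-c1ccc(Cl)cc1C(O)c1ccccc1`: 71 mg/kg

Among the compounds with values here, in a functional assay on the whole organism (strain CF-1) for inhibition, with Mus musculus as the target (a higher number here means that more compound is needed for the effect, a lower number that less compound is needed), compound 1 gives 45 mg/kg, one of only two numbers reported. Compound 3 gives 71 mg/kg, and the gap between the two is within the usual scatter, so they cannot be told apart. For compound 2 this assay reports only a limit, > 100 mg/kg, not a number; (the limit of > 100 mg/kg in this assay, at which 1 of the 3 values shown sits). Compound 4 `CCNCc1nnc(C)n1-c1ccc(Cl)cc1C(=O)c1ccccc1` has not yet been tested. Relative to compound 1 the change is ethylamino in place of dimethylamino on a saturated chain carbon bound to an aromatic carbon; the two have the same atoms, joined differently. Within the data shown here, no measured pair differs in just one place, so nothing shows how this change acts on its own. Compound 4 is therefore expected to stay close to compound 1, estimated at 50 mg/kg, with a likely range from 20 mg/kg to 130 mg/kg, which means an expected step of a 1.1-fold higher number from compound 1 to compound 4 (0.05 log units; within the scatter) no larger than the scatter.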

Compound 4, dose for half-maximal effect: 45 mg/kg
Compound 4: middle estimate off by 1.1-fold (0.05 log units), on the high side; low and high end bracket the measured number.
By their numbers in this assay, from the lowest: compounds 1, 4 and 3 (each within the scatter of the next). At a limit, above all of these: compound 2.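

In this assay, exchanging dimethylamino for ethylamino on a saturated chain carbon bound to an aromatic carbon gives no change at the digits printed from compound 1 to compound 4 (within the scatter). This first pair differing in one place shows that the number holds when the atoms of this amine are rearranged and an amine hydrogen is gained. Nothing measured here accounts for that outcome.

From the compounds shown here alone, whether this position tolerates a bigger change remains open. Butylamino, a longer chain, or a carboxylic acid in the same place could still shift the number in either direction.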